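Anilino-thiazole chalcones: shifting the methyl on the phenyl

This account rests on a few compounds, and the source may have more. Where it says the series, first, only, none or still open, it means among the compounds named here.

Measured so far in a functional assay on NCI-H460 cells (Homo sapiens) for cytotoxicity, read by MTT assay; on this read-out lower numbers stand for stronger inhibition and higher numbers for weaker inhibition:
- compound 1, `COc1cc(/C=C/C(=O)c2sc(Nc3ccc(Cl)c(Cl)c3)nc2C)cc(OC)c1OC`: > 25000 nM, a limit of the assay rather than a number
- compound 2, `COc1cc(/C=C/C(=O)c2sc(Nc3ccccc3C)nc2C)cc(OC)c1OC`: 6320 nM

Among the compounds with values here, compound 2 holds the only number in this assay; the other value in the set is a limit. Compound 1 sits at the limit of > 25000 nM in this assay, at which 1 of the 2 values shown sits. Within the data shown here, the one measured step, from compound 1 to compound 2, is an at least 3.9-fold lower number from compound 1 to compound 2 (0.59 log units; beyond the scatter), with 2-methylphenyl in place of 3,4-dichlorophenyl on a nitrogen on an aromatic ring.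

Compound 3, `COc1cc(/C=C/C(=O)c2sc(Nc3cccc(C)c3)nc2C)cc(OC)c1OC`, is not yet measured. It differs from compound 2 by 3-methylphenyl in place of 2-methylphenyl on a nitrogen on an aromatic ring; the two have the same atoms, joined differently, and cut one bond further out the change reads (2-methylphenyl)amino to (3-methylphenyl)amino. Among the measured compounds shown here, no measured step moves a methyl around the phenyl ring; the single step available replaces the whole substituted phenyl and bears on this change only loosely. A step within the usual scatter is therefore expected in this assay, in either direction, that is a 1.0-fold higher number from compound 2 to compound 3 (0.01 log units; within the scatter). Compound 3 is estimated at 6500 nM, within 2200 nM to 20000 nM.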

Compound 3, half-maximal inhibitory concentration: 19800 nM
The estimate for compound 3 lay 3.0-fold (0.48 log units) below the measured number; low and high end bracket the measured number.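

In this assay moving the methyl around the phenyl ring is enough on its own to give a 3.1-fold higher number from compound 2 to compound 3 (0.50 log units; beyond the scatter) as a modest step. The groups that leave and enter have the same atoms and the same counts, so this pair isolates the place of the methyl, which the earlier step, replacing the whole substituted phenyl, could not do. Of the two methylphenyl compounds, the 2-methylphenyl group of compound 2 gives the lower number. The step of an at least 1.2-fold lower number from compound 1 to compound 3 (0.10 log units; that floor lies within the scatter) is only a floor, and that floor lies within the scatter. Compound 1 stands at a limit of the assay and not a number: the limit of > 25000 nM in this assay, at which 1 of the 3 values shown sits.

The compounds shown give no reason for the gap between the two methylphenyl groups, and one pair cannot say whether it would hold on another cell line or with another group on the ring. From the compounds shown here alone, it also stays open whether an ethyl or a methoxy group on the phenyl, or a plain phenyl with no methyl at all, would give a number closer to that of compound 2 or of compound 3.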